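The source may report more compounds than this note shows. Statements on the series, on what has been measured and on what is new or still open speak of the compounds shown alone.

Measured compounds in a functional assay on the whole organism (blood, strain Wistar-Okamoto) with Rattus norvegicus as the target, with a stated time of 5 days; a higher number here means that more compound is needed for the effect, a lower number that less compound is needed:
- compound 1, `CC(C)(C)/N=C(\NC#N)Nc1ccncc1`: compound 1 gives 2.5 mg/kg
- compound 2, `CCC(C)(C)/N=C(\NC#N)Nc1ccncc1`: compound 2 gives 2.5 mg/kg
- compound 3, `Cn1nc(-c2ccc(Cl)cc2)cc1N/C(=N/C#N)NC(C)(C)C`: for compound 3 only a limit is reported, > 50 mg/kg

Compounds 1 and 2 share a core and differ at one place, (methyl in place of hydrogen on a saturated chain carbon, two bonds along the chain from a double-bonded nitrogen). The step of no change at the digits printed from compound 1 to compound 2 (within the scatter) lies within the scatter, so the two values are taken as equal.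

Compound 3 carries a different core. The difference between the two cores is not broken down here. The value of compound 3 is a limit, not a number; it is the limit of > 50 mg/kg in this assay, at which 1 of the 3 values shown sits.

Compound 4, `CCC(C)(C)N/C(=N\C#N)Nc1cc(-c2ccc(Cl)cc2)nn1C`, is not yet measured. It stands to compound 3 as compound 2 stands to compound 1: the difference is methyl in place of hydrogen on a saturated chain carbon, two bonds along the chain from an amine nitrogen. The two place lines are not identical, one reads two bonds along the chain from a double-bonded nitrogen, the other two bonds along the chain from an amine nitrogen, so this is the same kind of change rather than the same change.

Going by the values given here, the one measured instance of this kind of change, no change at the digits printed from compound 1 to compound 2 (within the scatter), left the minimum effective dose where it was. On that basis the expected step is a number no higher from compound 3 to compound 4 (the limit leaves the size open). Since compound 3 sits at the limit, compound 4 is expected to remain at or near that limit, estimated at 50 mg/kg, with a range of 20 mg/kg to 150 mg/kg, and most likely reported only as a limit again.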

Compound 4, minimum effective dose: 50 mg/kg
Estimate against measurement, compound 4: no gap at the digits printed, within the range that was stated.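

In this assay, the change from tert-butyl to 1,1-dimethylpropyl, carried over to the second core, gives a number no higher from compound 3 to compound 4 (the limit leaves the size open). Compound 3 is reported only as a limit, > 50 mg/kg, which is not a number and so gives this step no measured starting point. The minimum effective dose therefore rises on neither core, which is as far as the transfer can be read, and equal behaviour on the two cores is not shown: the same change on two cores in this assay, no change at the digits printed (within the scatter) from compound 1 to compound 2 and a number no higher (the limit leaves the size open) from compound 3 to compound 4; the limit leaves it open whether they differ

The compounds shown leave open whether the second core can reach a minimum effective dose in the range of compound 1 and compound 2 at all, since neither of its two members gives a value in that range, and neither alkyl group separates the two cores. They also leave open how a longer chain, a cyclohexyl ring or a hydroxyl group on the chain in place of tert-butyl would read on either core, and whether the 4-chlorophenyl group or the methyl on the ring of the second core carries the gap between the cores, as no single-place comparison between the cores stands here.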